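Ethynyl to cyano on a bis-trifluoromethyl aromatic ring

This account rests on a few compounds, and the source may have more. Where it says the series, first, only, none or still open, it means among the compounds named here.

Measured compounds in an ADME assay for pharmacokinetics, read by LC-MS, in phosphate buffer, with a stated time of 72 h, at pH 7.4, tested at 250 uM; on this read-out higher numbers stand for a longer-lived compound and lower numbers for a shorter-lived compound:
Compound 1, `C=Cc1cc(C(F)(F)F)cc(C(F)(F)F)c1`: > 50 h, a limit of the assay rather than a number.
Compound 2, `C#Cc1cc(C(F)(F)F)cc(C(F)(F)F)c1`: 0.3 h.

Compound 2 holds the only numeric half-life shown; the other result, for compound 1, sits at the limit of > 50 h in this assay, at which 1 of the 2 values shown sits. Compound 3, `N#Cc1cc(C(F)(F)F)cc(C(F)(F)F)c1`, differs from compound 2 by cyano in place of ethynyl on an aromatic carbon. Within the data shown here, no measured step covers this exchange. Among the measured compounds shown here, the single step known, an at least 160-fold lower number from compound 1 to compound 2 (2.22 log units; beyond the scatter), shows that one change on this aromatic carbon can move the half-life far. Since the ethynyl that leaves is the group carried by the short-lived compound 2, the expected step is a 170-fold higher number from compound 2 to compound 3 (2.22 log units; beyond the scatter). Compound 3 is estimated at 50 h, between 8 h and 300 h.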

Compound 3, half-life: > 50 h
Compound 3 gave a limit, no number (the forecaster's own chance of this, stated with the estimate: 65%); the middle value lies on the limit itself.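

Cyano in place of ethynyl gives an at least 160-fold higher number from compound 2 to compound 3 (2.22 log units; beyond the scatter) and so shows that the short half-life of compound 2 does not extend to every group with a triple bond at this aromatic carbon. Among the three compounds, only compound 2, with ethynyl, has a short half-life, whereas vinyl and cyano both reach the limit. The step from compound 1 to compound 3 cannot be read, since both values are limits: the limit of > 50 h in this assay, at which 2 of the 3 values shown sit.

Going by these compounds, how far the half-lives of compound 1 and compound 3 extend remains open. On these data alone, it is also open whether an amine or a carboxylic acid at this carbon would give a long-lived compound or a short-lived one.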